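Chloro in Place of Hydrogen on an Acrylamide Thiazole

This account rests on a few compounds, and the source may have more. Where it says the series, first, only, none or still open, it means among the compounds named here.

Two acrylamide compounds have been tested in a functional assay on HT-29 cells (Homo sapiens) for antiproliferative activity, read by MTT assay, with a stated time of 72 h; on this read-out higher numbers stand for weaker inhibition and lower numbers for stronger inhibition. Compound 1, `C=CC(=O)Nc1ccc(Cl)c(S(=O)(=O)N(C)C)c1`, gives only a limit, > 30000 nM, rather than a number. Among the compounds with values here, compound 2, `C=CC(=O)Nc1nc(-c2ccccc2)cs1`, is the only compound with a measured number in this assay, where compound 2 gives 6600 nM. Among the values shown, then, compound 2 stands alone as the single real number, the other entry being a limit of the assay.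

Compound 3, `C=CC(=O)Nc1nc(-c2ccccc2Cl)cs1`, has not yet been measured. It differs from compound 2 in one place: chloro in place of hydrogen on an aromatic carbon. Within the data shown here, no measured pair in this set shows what such a change does, so the expected step, a 1.5-fold lower number from compound 2 to compound 3 (0.17 log units; within the scatter), is a modest gain in inhibition that may not exceed the usual scatter. Compound 3 is therefore estimated at 4500 nM, with a range from 1500 nM to 15000 nM.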

Compound 3, half-maximal inhibitory concentration: 10200 nM
Estimate against measurement, compound 3: 2.3-fold (0.36 log units) below, within the range that was stated.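

In this assay, chloro in place of hydrogen on an aromatic carbon of the six-membered aromatic ring of carbon only, ortho to a large group, gives a 1.5-fold higher number from compound 2 to compound 3 (0.19 log units; within the scatter) and so cannot be told apart from no change at all. Within the data shown here, this is the first measured pair in the set, and it shows that this position accepts a chlorine atom with no effect on the read-out that stands clear of ordinary repeat variation. Nothing measured here bears on why the two compounds read alike.

As far as these compounds go, whether another group at this same place, such as an amine, a methoxy or a carboxylic acid, would shift the number beyond the scatter remains open. One pair also cannot show whether the same swap would behave alike on a different core, such as that of compound 1.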